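Swapping the Oxazole Ring Attached to Compound 1

This account rests on a few compounds, and the source may have more. Where it says the series, first, only, none or still open, it means among the compounds named here.

Compound 1 `CCOCCOC(=O)C(=O)Nc1nc(-c2cc(C)no2)cs1` is the reference point of this short series. For the measured compounds named here, in a functional assay on the whole organism with Rattus norvegicus as the target (on this read-out higher numbers stand for an effect only at larger amounts of compound and lower numbers for an effect already at smaller amounts), compound 1 gives 0.04 mg/kg, the lowest of the two numbers measured so far. Going by the values given here, the only other measured compound, compound 2 `CCOCCOC(=O)C(=O)Nc1nc(-c2cc(-c3c(F)cccc3Cl)no2)cs1`, gives 1.1 mg/kg in this assay; the step of a 28-fold higher number from compound 1 to compound 2 (1.44 log units; beyond the scatter) went with 2-chloro-6-fluorophenyl in place of methyl on an aromatic carbon.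

Compound 3 `CCOCCOC(=O)C(=O)Nc1nc(-c2cc(CO)on2)cs1` has not yet been measured. It differs from compound 1 in one place: 5-(hydroxymethyl)-1,2-oxazol-3-yl in place of 3-methyl-1,2-oxazol-5-yl on an aromatic carbon. The entering group brings one hydrogen-bond donor where the leaving group had none.

Among the compounds with values here, no measured step matches this change. Within the data shown here, the step from compound 1 to compound 2 shows only that the number moves a great deal when the group at this position is altered, so the change in compound 3 cannot be assumed to leave the number untouched; but that step involved a far larger group, so it gives no direct size. A modest rise with wide uncertainty is therefore expected: compound 3 is estimated to give 0.12 mg/kg, within a range from 0.03 mg/kg to 0.5 mg/kg. That estimate corresponds to an expected step of a 3.0-fold higher number from compound 1 to compound 3 (0.48 log units; beyond the scatter).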

Compound 3, dose for half-maximal effect: 1.8 mg/kg
Estimate against measurement, compound 3: 15-fold (1.18 log units) below; the whole stated range lies below it.
By their numbers in this assay, from the lowest: compound 1; then compounds 2 and 3 (each within the scatter of the next).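

A large group is not needed for a large change at this position: in this assay, the ring exchange goes with a 45-fold higher number from compound 1 to compound 3 (1.65 log units; beyond the scatter), although the leaving group has 6 heavy atoms and the entering group has 7. Compound 3 gives 1.8 mg/kg and compound 2 gives 1.1 mg/kg, two numbers within the usual scatter of each other, so a far larger aryl-bearing group and this small hydroxymethyl-bearing ring end up at the same level, and both lose the low number of compound 1. Nothing available here accounts for the size of this step.

The change in compound 3 alters two things together: the way the 1,2-oxazole ring is attached to the core, and the replacement of methyl by hydroxymethyl, which brings the hydrogen-bond donor. The compounds shown therefore leave open which of the two goes with the higher number, and how a methyl ether or an amine in place of the hydroxyl would read in this assay.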